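The source may hold more compounds than are shown below. What is called first, only, known or untested is meant among the compounds shown, and "the series" means these compounds.

Measured in a functional assay on A2780 cells (Homo sapiens) for antiproliferative activity; on this read-out higher numbers stand for weaker inhibition and lower numbers for stronger inhibition:
Compound 1 `NC1CCN(Cc2ccn3ncnc(Nc4ccccc4)c23)CC1`: 3700 nM
Compound 2 `Cc1ccccc1Nc1ncnn2ccc(CN3CCC(N)CC3)c12`: > 5000 nM (a limit)
Compound 3 `NC1CCN(Cc2ccn3ncnc(Nc4cccc(F)c4)c23)CC1`: > 5000 nM (a limit)

Compound 3 gives no number, only a limit, > 5000 nM. It sits with compound 2 at the limit of > 5000 nM in this assay, at which 2 of the 3 values shown sit.

Compound 4 `NC1CCN(Cc2ccn3ncnc(Nc4cccc(Br)c4)c23)CC1` keeps the shared core and the side chain of compound 3 and has bromo in place of fluoro on an aromatic carbon.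

Among the measured compounds shown here, no measured step makes this exchange. The nearest is an at least 1.3-fold higher number from compound 1 to compound 3 (0.13 log units; that floor lies within the scatter), for fluoro in place of hydrogen on an aromatic carbon. Next comes an at least 1.3-fold higher number from compound 1 to compound 2 (0.13 log units; that floor lies within the scatter), for methyl in place of hydrogen on an aromatic carbon. Both floors lie within the scatter, and the remaining pair shows a step that the two limits leave unreadable from compound 2 to compound 3. These steps give no ground for expecting a change of readable size or a particular direction in this assay.

The expected step is an at least 1.1-fold lower number from compound 3 to compound 4 (0.04 log units; that floor lies within the scatter), with nothing expected beyond the scatter. Compound 4 may well report only a limit too. For compound 4 the estimated value is 4500 nM, with an expected range from 1800 nM to 10000 nM.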

Compound 4, half-maximal inhibitory concentration: 2600 nM
Compound 4: the middle estimate sits 1.7-fold (0.24 log units) above what was measured, and the stated range covers the measured number.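

With bromo on the aromatic carbon meta to a large group, compound 4 gives a number in this assay, whereas fluoro at the same place in compound 3 gives only a limit. The exchange reads as an at least 1.9-fold lower number from compound 3 to compound 4 (0.28 log units; that floor lies within the scatter), and the comparison with the 2-methylphenyl compound reads as an at least 1.9-fold lower number from compound 2 to compound 4 (0.28 log units; that floor lies within the scatter); neither floor shows a change beyond the scatter. Against hydrogen at this place, the change reads as a 1.4-fold lower number from compound 1 to compound 4 (0.15 log units; within the scatter), so bromo is not separated from hydrogen here.

As far as these compounds go, the step between compound 2 and compound 3 cannot be read, and where those two compounds lie stays open: the limit of > 5000 nM in this assay, at which 2 of the 4 values shown sit. From the compounds shown here alone, whether methoxy, a nitrile or an amine at this place would give a step beyond the scatter also remains open.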